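Pyridyl isomers on a bis(hydroxyphenyl)pyridine core

The source may hold more compounds than are shown below. What is called first, only, known or untested is meant among the compounds shown, and "the series" means these compounds.

Measured compounds:
compound 1 `Oc1ccc(-c2cc(-c3ccco3)cc(-c3ccccc3O)n2)cc1`: 0%
compound 2 `Oc1ccc(-c2cc(-c3ccccn3)cc(-c3ccccc3O)n2)cc1`: "not determined" (no result reported)

In an assay on isolated protein for inhibition of DNA topoisomerase 1 (Homo sapiens), with a stated time of 30 min, tested at 20 uM (on this read-out lower numbers stand for a weaker effect and higher numbers for a stronger effect at the one concentration tested), compound 1 gives 0%. For compound 2 the result in this assay is "not determined" (no result reported), so compound 2 stands at no number of its own. Compound 3 `Oc1ccc(-c2cc(-c3cccnc3)cc(-c3ccccc3O)n2)cc1` differs from compound 2 by pyridin-3-yl in place of pyridin-2-yl on an aromatic carbon. For the measured compounds named here, no step between measured compounds is available, so the step from compound 2 to compound 3 in this assay is expected to lie within the scatter, with no clear direction. Compound 3 is expected to give 5% in this assay, in the range 0% to 25%.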

Compound 3, a percentage reported as inhibition, at one concentration (the size of the read-out at that concentration, not a potency): 0%
The estimate for compound 3 lay 5 percentage points above the measured number, and the stated range covers the measured number.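

In this assay, the position opposite the ring nitrogen now has a readable change: pyridin-3-yl in place of furan-2-yl gives no change at the digits printed from compound 1 to compound 3 (within the scatter). The step from compound 2 to compound 3 cannot be read, as compound 2 has no number, so the two pyridyl isomers cannot be compared. No measured evidence bears on this result.

On these data alone, whether an amine or a carboxylic acid at this position would give a read-out different from those of compound 1 and compound 3 remains open. Pyridin-2-yl also remains unresolved here.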